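A few compounds are considered here, and "the series" means these few. Any claim that something is new, unique, unknown or untested is made for them only; others in the source may bear on it.

Measured compounds:
- compound 1, `COc1ccc(-n2nc(-c3ccc(C(F)(F)F)cc3O)nc2-c2ccccc2O)cc1`, 86.6%
- compound 2, `Oc1cc(C(F)(F)F)ccc1-c1nc(-c2ccccc2O)n(-c2cccc(Cl)c2)n1`, 92.7%

Both compounds share one core and differ only in the group attached to an aromatic nitrogen. In a functional assay on PC-12 cells (Rattus norvegicus) for cytotoxicity, read by MTT assay, with stated times of 2 h and 24 h, tested at 5 uM (on this read-out higher numbers stand for a stronger effect at the one concentration tested and lower numbers for a weaker effect), compound 2 gives 92.7%, and compound 1 gives 86.6%. The change of 3-chlorophenyl in place of 4-methoxyphenyl on an aromatic nitrogen gave a number 6.1 percentage points higher from compound 1 to compound 2 (within the scatter), so the two numbers are not separated beyond the scatter and compound 2 stands beside compound 1 rather than apart from it.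

Compound 3, `Cc1ccc(-n2nc(-c3ccc(C(F)(F)F)cc3O)nc2-c2ccccc2O)c(C)c1`, has not yet been measured in this assay. It differs from compound 2 by 2,4-dimethylphenyl in place of 3-chlorophenyl on an aromatic nitrogen. Going by the values given here, the only measured step that bears on this change is the one from compound 1 to compound 2, which swapped the group on the same aromatic nitrogen and moved the read-out by a number 6.1 percentage points higher from compound 1 to compound 2 (within the scatter), within the scatter. Among the compounds with values here, nothing measured so far suggests that a different group on this nitrogen shifts the read-out much in either direction.

Compound 3 is therefore estimated at 88%, with a range from 74% to 98%. The expected step is a number 4.7 percentage points lower from compound 2 to compound 3 (within the scatter), which is expected to stay within the scatter.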

Compound 3, a percentage reported as activity, at one concentration (the size of the read-out at that concentration, not a potency): 93.3%
Compound 3: the middle estimate sits 5.3 percentage points below what was measured, within the range that was stated.
By their numbers in this assay, from the lowest: compounds 1, 2 and 3 (each within the scatter of the next).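

In this assay, a third group on the aromatic nitrogen does not separate from the first two: 2,4-dimethylphenyl in place of 3-chlorophenyl gives a number 0.6 percentage points higher from compound 2 to compound 3 (within the scatter), and 2,4-dimethylphenyl in place of 4-methoxyphenyl gives a number 6.7 percentage points higher from compound 1 to compound 3 (within the scatter). The earlier pair compared only a ring bearing chlorine with one bearing methoxy, whereas compound 3 brings a ring of carbon only, with two methyl groups and 8 heavy atoms against the 7 of the 3-chlorophenyl group, and across these three compounds the numbers still stay within the scatter of each other. No measurement offered here accounts for how closely these three groups read alike.

From the compounds shown here alone, all three groups are substituted phenyl rings, so it remains open whether something of another kind on this nitrogen, such as a simple amine on a longer carbon chain or a phenyl ring carrying a carboxylic acid, would stand apart from them. The two hydroxyl-bearing rings of the shared core stay the same throughout, and the single tested concentration leaves open whether these compounds would still read alike at lower concentrations.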